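Oxazole side-chain amides and amines in a resorcinol series

The compounds below may be only part of what the source reports. "The series", "measured", "known", "first", "only" and "open" are said of these compounds alone.

Measured compounds:
compound 1 `CCNCc1cc(-c2c(C(=O)NCC)noc2-c2cc(C(C)C)c(O)cc2O)on1` gives 45 nM in a functional assay on A2780 cells (Homo sapiens) for inhibition; on this read-out higher numbers stand for weaker inhibition and lower numbers for stronger inhibition
compound 2 `CCNC(=O)c1noc(-c2cc(C(C)C)c(O)cc2O)c1-c1cc(CNC(C)C)no1` gives 38 nM in this assay
compound 3 `CCNC(=O)c1noc(-c2cc(C(C)C)c(O)cc2O)c1-c1cc(C(=O)NC)no1` gives 100 nM in this assay

Compound 1 and compound 2 differ only by methyl in place of hydrogen on a saturated chain carbon bound to an amine nitrogen and a saturated chain carbon. The step of a 1.2-fold lower number from compound 1 to compound 2 (0.07 log units; within the scatter) is within the scatter, so the two are read as equal. Compound 3 carries a different group on the outer ring, the difference to compound 1 being (methylcarbamoyl in place of (ethylamino)methyl on an aromatic carbon). That exchange costs some potency: a 2.2-fold higher number from compound 1 to compound 3 (0.35 log units; beyond the scatter) and a 2.6-fold higher number from compound 2 to compound 3 (0.42 log units; beyond the scatter) both lie beyond the scatter, modest in size, and compound 3 has the highest number of the three.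

Compound 4 `CCNC(=O)c1cc(-c2c(C(=O)NCC)noc2-c2cc(C(C)C)c(O)cc2O)on1` is not yet measured. It differs from compound 3 by methyl in place of hydrogen on a saturated chain carbon bound to an amide-type nitrogen. This is the same kind of change as between compound 1 and compound 2, but not the same: there the added carbon sat on a saturated chain carbon bound to an amine nitrogen and a saturated chain carbon, here it sits on a saturated chain carbon bound to an amide-type nitrogen. Within the data shown here, only one earlier example exists, so the expectation rests on a single step.

Among the measured compounds shown here, the step expected here is a 1.2-fold lower number from compound 3 to compound 4 (0.07 log units; within the scatter), a small one, because a 1.2-fold lower number from compound 1 to compound 2 (0.07 log units; within the scatter) stayed within the scatter and nothing among the measured compounds points to a larger effect of one added carbon at this end of the molecule. Compound 4 is accordingly estimated at 85 nM, with a likely range from 40 nM to 180 nM.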

Compound 4, half-maximal inhibitory concentration: 43 nM
Compound 4: the middle estimate sits 2.0-fold (0.30 log units) above what was measured; measured number inside the range.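

In this assay, the change from methylcarbamoyl to ethylcarbamoyl gives a 2.3-fold lower number from compound 3 to compound 4 (0.37 log units; beyond the scatter), yet this step cannot be told apart from the one made by the same added methyl on the core of compound 1: the same change on two cores in this assay, a 1.2-fold lower number (0.07 log units; within the scatter) from compound 1 to compound 2 and a 2.3-fold lower number (0.37 log units; beyond the scatter) from compound 3 to compound 4, 2.0-fold (0.29 log units) apart, within the scatter of two such steps. The methyl addition can therefore be carried between these two cores without a measurable difference in its effect, although the step lies beyond the scatter on one core and within it on the other; two pairs do not fix a size for the step, nor do they show that it would hold on any further core. The ethylcarbamoyl group also stands level with both amine side chains, with a 1.1-fold higher number from compound 2 to compound 4 (0.05 log units; within the scatter) and a 1.0-fold lower number from compound 1 to compound 4 (0.02 log units; within the scatter), so among these compounds only the methylcarbamoyl of compound 3 stands apart.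

Still open, on these data alone, is how far the trend in the amide side chain extends: a propylcarbamoyl or a longer chain could continue it, level off or reverse it. A carboxylic acid or a primary amine in the same place would show whether the outer group tolerates wider changes than those seen among these four compounds.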